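A Phenoxy Group Replaces the Hydantoin Arm

This account rests on a few compounds, and the source may have more. Where it says the series, first, only, none or still open, it means among the compounds named here.

Compound 1 `CN(C)[C@H]1C[C@H](c2c[nH]c3ccc(CC(N)=O)cc32)C1` and compound 2 `CN(C)[C@H]1C[C@H](c2c[nH]c3ccc(CN4C(=O)CNC4=O)cc32)C1` share one core and differ in a single group. In an assay on CHO-K1 cells for binding affinity to 5-hydroxytryptamine receptor 1B (Homo sapiens) (on this read-out higher numbers stand for weaker inhibition and lower numbers for stronger inhibition), compound 1 gives 1350 nM, while compound 2 gives 6310 nM, the higher of the two numbers, the change being a 4.7-fold higher number from compound 1 to compound 2 (0.67 log units; beyond the scatter). Compound 3 `CN(C)[C@H]1C[C@H](c2c[nH]c3ccc(Oc4ccccc4)cc32)C1` carries phenoxy in place of (2,5-dioxoimidazolidin-1-yl)methyl on an aromatic carbon. Among the measured compounds shown here, no measured step involves a phenoxy group; the one step known, from compound 1 to compound 2, only shows that changing this group moves the number beyond the scatter. The step from compound 2 to compound 3 is expected to be a 3.2-fold lower number from compound 2 to compound 3 (0.50 log units; beyond the scatter), with wide uncertainty. Compound 3 is therefore estimated at 2000 nM, between 300 nM and 15000 nM.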

Compound 3, half-maximal inhibitory concentration: 97.7 nM
Estimate against measurement, compound 3: 20-fold (1.31 log units) above; measured number outside the range, below it.
By their numbers in this assay, from the lowest: compound 3; then compound 1; then compound 2.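

In this assay this position on the aromatic ring tolerates far more than the first two compounds showed: phenoxy brings a 65-fold lower number from compound 2 to compound 3 (1.81 log units; beyond the scatter) and also a 14-fold lower number from compound 1 to compound 3 (1.14 log units; beyond the scatter), so both polar-free comparisons aside, a group with no saturated chain carbon can give the lowest number of the three. No measurement shown gives a reason for this gain. Still open, from the compounds shown here alone, is whether it follows the oxygen link or the six-membered aromatic ring, since phenoxy brings both at once; a methoxy group and a benzyl group would separate the two.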